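Swapping Cyclopropyl for a Dimethylaminoethyl Chain

This account rests on a few compounds, and the source may have more. Where it says the series, first, only, none or still open, it means among the compounds named here.

Measured compounds:
- Compound 1, `COc1ncc(-c2ccc3nc(NC(=O)NC4CC4)sc3c2)cc1NS(=O)(=O)c1ccc(F)cc1`: in a functional assay on U-87MG ATCC cells for antiproliferative activity against U-87 MG (Homo sapiens), read by MTT assay, with a stated time of 72 h (a lower number here means a stronger inhibitor, a higher number a weaker inhibitor), compound 1 gives 520 nM.
- Compound 2, `CCN(CC)CCNC(=O)Nc1nc2ccc(-c3cnc(OC)c(NS(=O)(=O)c4ccc(F)cc4)c3)cc2s1`: compound 2 gives 390 nM.
- Compound 3, `COc1ncc(-c2ccc3nc(NC(=O)NCCN4CCN(C)CC4)sc3c2)cc1NS(=O)(=O)c1ccc(F)cc1`: compound 3 gives 440 nM.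

Compound 1 has the highest of the three numbers, but its gaps to the other two are small: a 1.3-fold lower number from compound 1 to compound 2 (0.12 log units; within the scatter) and a 1.2-fold lower number from compound 1 to compound 3 (0.07 log units; within the scatter), both within the scatter, so the three compounds cannot be told apart on these numbers.

The step to compound 4, `COc1ncc(-c2ccc3nc(NC(=O)NCCN(C)C)sc3c2)cc1NS(=O)(=O)c1ccc(F)cc1`, changes compound 1 in one place: 2-(dimethylamino)ethyl in place of cyclopropyl on an amide-type nitrogen. The two measured steps that bear on this one both replace the same cyclopropyl with a chain carrying a nitrogen at the same position, and both gave only a small drop within the scatter. The 2-(dimethylamino)ethyl group is the shortest such chain of the set, so no new effect is expected. Compound 4 is therefore expected to sit close to compound 1, with a step of about a 1.2-fold lower number from compound 1 to compound 4 (0.06 log units; within the scatter), not beyond the scatter. The estimate for compound 4 in this assay is 450 nM, with a likely range from 250 nM to 800 nM.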

Compound 4, half-maximal inhibitory concentration: 1020 nM
Compound 4: middle estimate off by 2.3-fold (0.36 log units), on the low side; measured number above the stated range.
By their numbers in this assay, from the lowest: compounds 2, 3, 1 and 4 (each within the scatter of the next, the first and the last beyond it).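

In this assay, among the compounds shown here, changing the group on the saturated chain carbon, two bonds along the chain from the amide-type nitrogen, now gives steps beyond the scatter, which no earlier pair of compounds did: a 2.6-fold higher number from compound 2 to compound 4 (0.42 log units; beyond the scatter) with dimethylamino in place of diethylamino, and a 2.3-fold higher number from compound 3 to compound 4 (0.37 log units; beyond the scatter) with dimethylamino in place of 4-methylpiperazin-1-yl. These steps are modest, but they show that having a nitrogen-bearing chain on the amide-type nitrogen does not settle the number, since the group carried on that chain also counts, whereas a 2.0-fold higher number from compound 1 to compound 4 (0.29 log units; within the scatter) stays within the scatter and so cannot be read as a real change from cyclopropyl. No measurement here accounts for the difference among these chain groups.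

Still open, going by these compounds, is whether another amine at the same place, such as pyrrolidin-1-yl or morpholin-4-yl, would fall with compound 4 or with compound 2 and compound 3. Also open, on these data alone, is what a longer chain would do, with three or four carbons separating the amine from the amide-type nitrogen.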